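Swapping the aryl amide substituent on a shared core

The source may report more compounds than this note shows. Statements on the series, on what has been measured and on what is new or still open speak of the compounds shown alone.

Measured compounds:
compound 1 `Cc1cc(C)cc(NC(=O)CN2CCC(c3cccc[n+]3[O-])CC2)c1`: 76%
compound 2 `Cc1cc(C(=O)NCN2CCC(c3cccc[n+]3[O-])CC2)ccc1F`: 67%
compound 3 `Cc1cccc(NC(=O)CN2CCC(c3ccccc3)CC2)c1`: 37%

Of the compounds shown here, three have been measured in a functional assay on HEK293 cells for agonist activity at D(4) dopamine receptor (Homo sapiens), read by FLIPR; a lower number here means a smaller maximal response, a higher number a larger maximal response. Compound 1 gives the highest of the three numbers, with 76%. Its nearest neighbour is compound 2, whose value of 67% lies within the usual scatter of compound 1, so the two cannot be ranked against each other. Compound 3, at 37%, sits furthest away, and this gap is beyond the scatter. Among the compounds with values here, compound 3 also differs from compound 1 in more than one place, so no single structural step between them is defined here.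

Compound 4 `O=C(CN1CCC(c2cccc[n+]2[O-])CC1)Nc1ccc(F)cc1F` has not yet been measured. It differs from compound 1 in one place: 2,4-difluorophenyl in place of 3,5-dimethylphenyl on an amide-type nitrogen. The rest of the molecule, including the shared core and the amide link, is unchanged.

Within the data shown here, nothing measured so far isolates this particular exchange, so the size of the step in this assay is uncertain. A small downward step, at most modestly beyond the scatter, is expected from compound 1 to compound 4, as a number 12 percentage points lower from compound 1 to compound 4 (beyond the scatter). The estimated maximal response of compound 4 is 64%, with a range of 42% to 84%.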

Compound 4, largest response reached (reported as efficacy), in percent of the reference or control that the assay uses: 74%
Compound 4: middle estimate off by 10 percentage points, on the low side; low and high end bracket the measured number.
By their numbers in this assay, from the lowest: compound 3; then compounds 2, 4 and 1 (each within the scatter of the next).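

In this assay, placing 2,4-difluorophenyl instead of 3,5-dimethylphenyl on the amide-type nitrogen gives a number 2 percentage points lower from compound 1 to compound 4 (within the scatter), and this step lies within the scatter, so the two compounds cannot be ranked. Within the data shown here, this is the only exchange in the set that isolates a change at this position, and it shows that the maximal response can hold up when a ring carrying two fluorines replaces one carrying two methyl groups, with the shared core left unchanged. The two groups have the same count of heavy atoms and the same aromatic ring of carbon, but they differ in their atoms, so this one pair shows that the response does not depend on keeping the methyl groups, though it says nothing for other groups. No measurement here accounts for the similar responses, so the reason remains unknown.

As far as these compounds go, whether this holds for other groups at this position remains open, for example a phenyl ring bearing a methoxy group, an amine or a carboxylic acid. A single pair also cannot show how much either fluorine or either methyl group contributes on its own, which would take rings bearing just one of them.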